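This account rests on a few compounds, and the source may have more. Where it says the series, first, only, none or still open, it means among the compounds named here.

Working notes on the series. Compound 2 `Cc1nn(-c2ccccc2)cc1/C=N/Nc1nc(Nc2ccccc2)nc(Nc2ccc(S(N)(=O)=O)cc2)n1` and compound 1 `NS(=O)(=O)c1ccc(Nc2nc(N/N=C/c3ccc(C(F)(F)F)cc3)nc(Nc3ccccc3)n2)cc1` share one core and differ only in the group on the carbon with a double bond to nitrogen. In a functional assay on Malme-3M cells (Homo sapiens) for inhibition, read by sulforhodamine B assay, with a stated time of 48 h (a higher number here means that more compound is tolerated, a lower number that less compound is tolerated), compound 1 gives 8150 nM and compound 2 gives 6130 nM. Going by the values given here, compound 2 stands lowest of the two numbers, but its only neighbour is compound 1 and the step of a 1.3-fold lower number from compound 1 to compound 2 (0.12 log units; within the scatter) lies within the scatter, so no order between the two can be read. Compound 3 `NS(=O)(=O)c1ccc(Nc2nc(N/N=C/c3ccccn3)nc(Nc3ccccc3)n2)cc1` is a further variation at the same place: pyridin-2-yl in place of 3-methyl-1-phenyl-1H-pyrazol-4-yl on a carbon with a double bond to nitrogen. Among the compounds with values here, the one measured step that bears on this change is the exchange at the same position from compound 1 to compound 2, which stayed within the scatter. A further exchange at this position is therefore expected to give no step beyond the scatter in this assay, that is an estimated 1.1-fold higher number from compound 2 to compound 3 (0.03 log units; within the scatter). For compound 3 the estimate in this assay is 6500 nM, with a range from 2500 nM to 17000 nM.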

Compound 3, concentration lethal to 50% of the cells: 6280 nM
Compound 3: the middle estimate sits 1.0-fold (0.01 log units) above what was measured; measured number inside the range.
By their numbers in this assay, from the lowest: compounds 2, 3 and 1 (each within the scatter of the next).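

In this assay, pyridin-2-yl adds a third group at this position, and both new steps, a 1.0-fold higher number from compound 2 to compound 3 (0.01 log units; within the scatter) and a 1.3-fold lower number from compound 1 to compound 3 (0.11 log units; within the scatter), stay within the scatter, so no order can be read among the three compounds. The exchange of the two aromatic rings of 3-methyl-1-phenyl-1H-pyrazol-4-yl for the single aromatic ring of pyridin-2-yl shows that, for these compounds, this larger change of group on the carbon with a double bond to nitrogen also gives no readable step. Nothing available explains this result.

From the compounds shown here alone, it remains open whether a group without an aromatic ring at this position, such as an amine, a carboxylic acid or a longer alkyl chain, would give a step beyond the scatter. Going by these compounds, it also remains open whether changes elsewhere on the shared core would do so.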